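A few compounds are considered here, and "the series" means these few. Any claim that something is new, unique, unknown or untested is made for them only; others in the source may bear on it.

Series notes. Compound 1 `O=C(c1ccco1)[C@H]1C[C@H]2CNC[C@H]2C1` and compound 2 `CNC(=O)[C@H]1C[C@H]2CNC[C@H]2C1` share one core; compound 3 `O=C(c1ccco1)[C@H]1C[C@@H]2CNC[C@@H](C2)C1` and compound 4 `CNC(=O)[C@H]1C[C@@H]2CNC[C@@H](C2)C1` share another. How the core of compound 1 and the core of compound 3 differ is not broken down here.

In an assay on SHEP1 cells for displacement of a labelled ligand from Neuronal acetylcholine receptor; alpha4/beta2 (Homo sapiens), read by scintillation counting, with a stated time of 2 h (a higher number here means a weaker inhibitor, a lower number a stronger inhibitor), compound 1 gives 13 nM. Compound 2 gives 180 nM in this assay, and the step of a 14-fold higher number from compound 1 to compound 2 (1.14 log units; beyond the scatter) goes with the change (methylamino in place of furan-2-yl on a carbonyl carbon). Compound 3 gives 110 nM in this assay; set against compound 2 the two values lie within the scatter, while the gap to compound 1 is beyond it.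

Compound 4 carries the change methylamino in place of furan-2-yl on a carbonyl carbon relative to compound 3. The place is the same word for word in both pairs, so this is the same change, seen so far only once among the measured compounds, in the pair of compound 1 and compound 2. The step expected here is a 12-fold higher number from compound 3 to compound 4 (1.07 log units; beyond the scatter), resting on the earlier step of a 14-fold higher number from compound 1 to compound 2 (1.14 log units; beyond the scatter) applied to the value of compound 3, 110 nM. Because that earlier step a 14-fold higher number from compound 1 to compound 2 (1.14 log units; beyond the scatter) is a single instance on a different core, the range is kept wide. Compound 4 is expected to give 1300 nM in this assay, with an estimated range from 400 nM to 4000 nM.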

Compound 4, inhibition constant: 1.9 nM
Compound 4: the middle estimate sits 680-fold (2.84 log units) above what was measured, and the stated range ends above it.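

Working notes on the series. In this assay the change of methylamino in place of furan-2-yl on a carbonyl carbon gives a 58-fold lower number from compound 3 to compound 4 (1.76 log units; beyond the scatter) and so runs in the opposite direction to the step on the core of compound 1, which means that neither its size nor its direction carried from one core to the other: the same change on two cores in this assay, a 14-fold higher number (1.14 log units; beyond the scatter) from compound 1 to compound 2 and a 58-fold lower number (1.76 log units; beyond the scatter) from compound 3 to compound 4, 800-fold (2.90 log units) apart, beyond the scatter of two such steps. For these two cores, a step read on one therefore gives no usable guide to the same change on the other, and each core needs its own measured pair. This does not show why the two cores part, nor how general the reversal is, since it rests on one pair per core and on this single change in this one assay.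

Open, on these data alone, is whether the reversal belongs to this particular pair of groups or extends to others on the same carbonyl carbon, and matched pairs on both cores carrying a dimethylamino group, an ethylamino group, a phenyl ring or a longer chain would test that. Also open, as far as these compounds go, is whether the same opposite behaviour appears at any other place on these two cores.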